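Compound 1 to compound 3: changing the sulfonyl substituent

This account rests on a few compounds, and the source may have more. Where it says the series, first, only, none or still open, it means among the compounds named here.

Measured so far in an ADME assay on HeLa cells (Homo sapiens) for cytotoxicity, read by XTT assay (a higher number here means a weaker inhibitor, a lower number a stronger inhibitor), for this series
- compound 1 `N#C/C(=C\c1cc(Cc2ccc(Cl)c(Cl)c2)ccc1F)S(=O)(=O)c1ccccn1` gives 87000 nM
- compound 2 `CS(=O)(=O)/C(C#N)=C/c1cc(Cc2ccc(Cl)c(Cl)c2)ccc1OC(F)(F)F` gives 73000 nM

Compound 1 lies within the scatter of compound 2, so it holds no distinct rank on these numbers. Compound 3 `CS(=O)(=O)/C(C#N)=C/c1cc(Cc2ccc(Cl)c(Cl)c2)ccc1F` has methyl in place of pyridin-2-yl on a sulfonyl sulfur and is otherwise the same as compound 1. For the measured compounds named here, no measured step isolates this change. Compound 2 also carries methylsulfonyl and sits at a similar level (73000 nM), so no step beyond the scatter is expected in this assay for this change. The expected move is a 1.1-fold lower number from compound 1 to compound 3 (0.04 log units; within the scatter) and it stays within the scatter. Compound 3 is expected at 80000 nM (estimated range 35000 nM to 180000 nM).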

Compound 3, half-maximal inhibitory concentration: 125000 nM
Estimate against measurement, compound 3: 1.6-fold (0.19 log units) below; measured number inside the range.
By their numbers in this assay, from the lowest: compounds 2, 1 and 3 (each within the scatter of the next).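

In this assay, for the compounds shown here, the pair with methyl in place of pyridin-2-yl on a sulfonyl sulfur gives a 1.4-fold higher number from compound 1 to compound 3 (0.16 log units; within the scatter) and so offers the first direct reading at this position, with no step beyond the scatter. Fluoro in place of trifluoromethoxy on an aromatic carbon gives a 1.7-fold higher number from compound 2 to compound 3 (0.23 log units; within the scatter) and likewise stays within the scatter. No evidence bears on these readings.

From the compounds shown here alone, whether a longer chain such as ethyl, or an amine, on the sulfonyl sulfur would give a step beyond the scatter remains open.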